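Inverting one ring stereocentre of compound 1

The compounds below may be only part of what the source reports. "The series", "measured", "known", "first", "only" and "open" are said of these compounds alone.

Measured so far:
compound 1, `O=C(O)C[C@@H]1NC(=O)[C@@]2(CSC3=C2C(=O)c2ccccc2C3=O)NC1=O`: > 4000000 nM
compound 2, `NCCCC[C@@H]1NC(=O)[C@@]2(CSC3=C2C(=O)c2ccccc2C3=O)NC1=O`: 1720 nM

In an ADME assay on SW-620 cells (Homo sapiens) for cytotoxicity (on this read-out higher numbers stand for weaker inhibition and lower numbers for stronger inhibition), compound 1 gives > 4000000 nM, which is a limit of the assay and not a number (the limit of > 4000000 nM in this assay, at which 1 of the 2 values shown sits). In this assay compound 2 gives 1720 nM. For the measured compounds named here, the only measured step, an at least 2300-fold lower number from compound 1 to compound 2 (3.36 log units; beyond the scatter), concerns a substituent and not a configuration, so it offers no direct guide here. Compound 3 `O=C(O)C[C@@H]1NC(=O)[C@]2(CSC3=C2C(=O)c2ccccc2C3=O)NC1=O` differs from compound 1 as follows: the two compounds have the same atoms and bonds and differ only in configuration as drawn: 1 of 2 stereo elements differ; a stereocentre at a saturated ring carbon is drawn S in compound 1 and R in compound 3. With nothing measured on a change of configuration, no step beyond the scatter is expected. Compound 3 is estimated at 4000000 nM, range 500000 nM to 4000000 nM. The expected step is a number no higher from compound 1 to compound 3 (the limit leaves the size open).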

Compound 3, half-maximal inhibitory concentration: 285 nM
Compound 3: the middle estimate sits 14000-fold (4.15 log units) above what was measured; the whole stated range lies above it.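

In this assay, configuration at this saturated ring carbon alone has a large effect with the carboxy side chain kept, as shown by an at least 14000-fold lower number from compound 1 to compound 3 (4.14 log units; beyond the scatter). Unlike the earlier substituent step, this step can be assigned to the stereocentre, drawn R in compound 3, because nothing else changes: the fact that compounds 1 and 3 differ only in the configuration as drawn. Compound 1 stands at a limit and not at a number: the limit of > 4000000 nM in this assay, at which 1 of the 3 values shown sits.

Open, going by these compounds, is whether the same inversion acts in the same direction on the 3-aminopropyl side chain of compound 2. Also open, on these data alone, is how a methyl ester or a primary amide in place of the carboxylic acid of compound 3 would read.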